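Cyclopropyl for Isopropyl on the Sulfonyl Sulfur

The source may hold more compounds than are shown below. What is called first, only, known or untested is meant among the compounds shown, and "the series" means these compounds.

Measured compounds:
compound 1 `CC(=O)N1CCc2nc(C#Cc3ccccc3)sc2C1`: 90 nM
compound 2 `O=C(C1CCOCC1)N1CCc2nc(C#Cc3ccccc3)sc2C1`: only a limit, > 10000 nM
compound 3 `CC(C)S(=O)(=O)N1CCc2nc(C#Cc3ccccc3)sc2C1`: 11 nM

In an assay on HEK293 cells for negative allosteric modulation of metabotropic glutamate receptor 5 (Homo sapiens), read by FLIPR, with a stated time of 1 h (a lower number here means a stronger inhibitor, a higher number a weaker inhibitor), compound 3 has the lowest of the two numbers given; its nearest neighbour is compound 1, the gap being an 8.2-fold lower number from compound 1 to compound 3 (0.91 log units; beyond the scatter). Compound 2 gives only a limit in this assay, (the limit of > 10000 nM in this assay, at which 1 of the 3 values shown sits). Compound 4 `O=S(=O)(C1CC1)N1CCc2nc(C#Cc3ccccc3)sc2C1` is not yet measured. It differs from compound 3 in one place: cyclopropyl in place of isopropyl on a sulfonyl sulfur.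

Among the measured compounds shown here, none of the measured steps alters the carbon group on a sulfonyl sulfur. The step of an at least 110-fold higher number from compound 1 to compound 2 (2.04 log units; beyond the scatter) changes the group on a carbonyl carbon and is large, but it replaces methyl with a ring of six members, not one three-carbon group with another. The steps of an 8.2-fold lower number from compound 1 to compound 3 (0.91 log units; beyond the scatter) and an at least 900-fold lower number from compound 2 to compound 3 (2.95 log units; beyond the scatter) change the whole group on the ring nitrogen and leave the sulfonyl untouched. The present change is therefore expected to give no step beyond the scatter in this assay, a 1.1-fold higher number from compound 3 to compound 4 (0.04 log units; within the scatter). Compound 4 is estimated at 12 nM, within 4 nM to 40 nM.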

Compound 4, half-maximal inhibitory concentration: 34 nM
Estimate against measurement, compound 4: 2.8-fold (0.45 log units) below; the measured number falls inside the stated range.
By their numbers in this assay, from the lowest: compound 3; then compound 4; then compound 1. At a limit, above all of these: compound 2.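

In this assay the carbon group on the sulfonyl sulfur proves to matter: cyclopropyl in place of isopropyl gives a 3.1-fold higher number from compound 3 to compound 4 (0.49 log units; beyond the scatter) even though the count of heavy atoms stays the same. The sulfonyl compounds still keep their lead over the acetyl compound, with a 2.6-fold lower number from compound 1 to compound 4 (0.42 log units; beyond the scatter) for this second sulfonyl group, so the gain seen with isopropylsulfonyl is not confined to that one group. The step of an at least 290-fold lower number from compound 2 to compound 4 (2.46 log units; beyond the scatter) rests on a limit and gives a bound only.

The compounds shown offer no measured property that accounts for the step between the two three-carbon groups. On these data alone, whether a longer chain, a phenyl ring or a dimethylamino group on the sulfonyl sulfur would give a lower or a higher number stays open.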